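Swapping a dimethylamino for a piperidine in this series

The source may report more compounds than this note shows. Statements on the series, on what has been measured and on what is new or still open speak of the compounds shown alone.

Measured compounds:
compound 1 `CCC(=O)Nc1cccc(Oc2nc(Nc3ccc(N(C)C)cc3OC)ncc2Cl)c1` — 80.6%
compound 2 `CCC(=O)Nc1cccc(Oc2nc(Nc3ccc(N4CCN(C)CC4)cc3)ncc2Cl)c1` — 92.9%
compound 3 `CCC(=O)Nc1cccc(Oc2ccnc(Nc3ccc(N4CCN(C)CC4)cc3)n2)c1` — 85.6%

In an assay on isolated protein for inhibition of NUAK family SNF1-like kinase 1 (Homo sapiens), read by ADP-Glo, with a stated time of 60 min, tested at 10 uM, in the presence of a further agent that is not named here (a lower number here means less inhibition, a higher number more inhibition at the concentration tested (going by the name of the read-out)), compound 1 stands lowest of the three; compound 3 lies within the scatter of it, while compound 2 sits beyond the scatter above it. Within the data shown here, the only single step measured is a number 7.3 percentage points lower from compound 2 to compound 3 (within the scatter), which says nothing directly about the change studied here. Compound 4 `CCC(=O)Nc1cccc(Oc2nc(Nc3ccc(N4CCCCC4)cc3OC)ncc2Cl)c1` differs from compound 1 by piperidin-1-yl in place of dimethylamino on an aromatic carbon. Among the measured compounds shown here, no measured step bears on that change, so no shift beyond the scatter is expected in this assay , and compound 4 is estimated at 84% (range 70% to 95%), an expected step of a number 3.4 percentage points higher from compound 1 to compound 4 (within the scatter).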

Compound 4, a percentage reported as inhibition, at one concentration (the size of the read-out at that concentration, not a potency): 13.9%
Compound 4: middle estimate off by 70.1 percentage points, on the high side; the whole stated range lies above it.
By their numbers in this assay, from the lowest: compound 4; then compounds 1, 3 and 2 (each within the scatter of the next, the first and the last beyond it).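

The earlier compounds shown here gave no step at this position, but in this assay piperidin-1-yl in place of dimethylamino gives a number 66.7 percentage points lower from compound 1 to compound 4 (beyond the scatter). This aromatic carbon, meta to a methoxy group and para to a large group, is therefore sensitive to the change from dimethylamino to piperidin-1-yl, even though the counts of hydrogen-bond donors and acceptors stay the same. Nothing available explains this drop.

On these data alone, it remains open whether a pyrrolidin-1-yl or morpholin-4-yl group here would keep the inhibition of compound 1 or lose it as compound 4 does.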